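The compounds below may be only part of what the source reports. "The series", "measured", "known", "first", "only" and "open" are said of these compounds alone.

Measured compounds in an assay on CHO cells for displacement of a labelled ligand from adenosine receptor A1 (Homo sapiens), read by scintillation counting, with a stated time of 120 min, tested at 10 uM; a lower number here means less inhibition, a higher number more inhibition at the concentration tested (going by the name of the read-out):

Compound 1 `CC(C)N1CCN(Cc2csc(N)c2C(=O)c2ccc(Cl)cc2)CC1`: 0%
Compound 2 `Nc1scc(CN2CCN(c3ccc(Cl)cc3Cl)CC2)c1C(=O)c1ccc(Cl)cc1`: 0%
Compound 3 `Nc1scc(CN2CCN(c3ccc(Cl)cc3F)CC2)c1C(=O)c1ccc(Cl)cc1`: 0%

Compound 3 stands level with compounds 1 and 2: in this assay compound 3 gives 0%, and the step of no change at the digits printed from compound 1 to compound 3 (within the scatter) as well as the step of no change at the digits printed from compound 2 to compound 3 (within the scatter) shows nothing beyond the scatter. All three compounds share the same core and differ only in the group on the amine nitrogen in the ring; none of the variations tried so far has moved the read-out.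

Compound 4 `Nc1scc(CN2CCN(c3ccc(Cl)c(C(F)(F)F)c3)CC2)c1C(=O)c1ccc(Cl)cc1` has not yet been measured. Its difference from compound 3 is 4-chloro-3-(trifluoromethyl)phenyl in place of 4-chloro-2-fluorophenyl on an amine nitrogen in a ring.

Within the data shown here, the steps that bear on this change are those in which the group on that ring nitrogen was exchanged: no change at the digits printed from compound 1 to compound 2 (within the scatter), no change at the digits printed from compound 1 to compound 3 (within the scatter) and no change at the digits printed from compound 2 to compound 3 (within the scatter). Each of these was flat. Nothing in the measured compounds suggests that a further exchange of the aromatic group on the ring nitrogen would produce a step beyond the scatter, so for compound 4 the expected step of no change at the digits printed from compound 3 to compound 4 (within the scatter) is essentially none.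

Compound 4 is therefore estimated at 0%, with a range from -8% to 12%.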

Compound 4, a percentage reported as inhibition, at one concentration (the size of the read-out at that concentration, not a potency): 0%
Compound 4: middle estimate and measured number agree at the digits printed; the measured number falls inside the stated range.
By their numbers in this assay, from the lowest: compounds 1, 2, 3 and 4 (each within the scatter of the next).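

In this assay, the step is no change at the digits printed from compound 3 to compound 4 (within the scatter), so the flat result now extends to 4-chloro-3-(trifluoromethyl)phenyl, which has 11 heavy atoms against 8 in the group it replaces and carries trifluoromethyl where 2,4-dichlorophenyl and 4-chloro-2-fluorophenyl carry a single halogen as their second substituent. The same holds against the other two compounds, with no change at the digits printed from compound 2 to compound 4 (within the scatter) and no change at the digits printed from compound 1 to compound 4 (within the scatter), so the read-out at this ring nitrogen has not separated isopropyl or any of the three substituted phenyl groups. No measured evidence is available to explain this flat result.

Going by these compounds, with all four compounds reading alike, it remains open whether any group on this nitrogen can move the read-out, for instance a phenyl ring bearing a primary amine or a carboxylic acid, or a longer chain in place of isopropyl. Also open, on these data alone, is whether changes elsewhere on the shared core, such as replacing the free amine or the 4-chlorophenyl on the carbonyl with a hydroxyl or an unsubstituted phenyl, would give any inhibition in this assay at all.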